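Methoxy on the Aryl Ring of a Thiosemicarbazone Hydrazone

A few compounds are considered here, and "the series" means these few. Any claim that something is new, unique, unknown or untested is made for them only; others in the source may bear on it.

Compound 1, `CC1=CC[C@H](C(C)(C)NC(=S)N/N=C/c2ccc(F)cc2)CC1`, gives in a functional assay on OVCAR-3 cells (Homo sapiens) for inhibition, read by sulforhodamine B assay, with a stated time of 48 h (a higher number here means a weaker inhibitor of growth, a lower number a stronger inhibitor of growth), a limit of > 100000 nM.
Compound 2, `CC1=CC[C@H](C(C)(C)NC(=S)N/N=C/c2ccco2)CC1`, gives in this assay 13800 nM.
Compound 3, `CC1=CC[C@H](C(C)(C)NC(=S)N/N=C(\C)c2ccccc2)CC1`, gives in this assay a limit of > 100000 nM.

Compound 3 therefore stands only at a limit, not at a number, and it shares that limit with compound 1 (the limit of > 100000 nM in this assay, at which 2 of the 3 values shown sit). Compound 4, `COc1ccc(/C(C)=N/NC(=S)NC(C)(C)[C@H]2CC=C(C)CC2)cc1`, differs from compound 3 by methoxy in place of hydrogen on an aromatic carbon. Going by the values given here, no measured step changes that same ring in that way; the only measured step, an at least 7.2-fold lower number from compound 1 to compound 2 (0.86 log units; beyond the scatter), swaps the whole aryl group for a furan ring and so bears on compound 4 only loosely. Going by these compounds, since compound 3 sits at a limit, its true value is unknown, and a small change on the ring gives no firm direction. The number for compound 4 is expected to stay near that limit, with an at least 1.2-fold lower number from compound 3 to compound 4 (0.09 log units; that floor lies within the scatter) as the likely step. In this assay compound 4 is estimated at 80000 nM, within 20000 nM to 300000 nM.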

Compound 4, concentration for total growth inhibition: > 100000 nM
Compound 4 ended at the assay's limit; the forecaster's own chance of this, stated with the estimate: 60%; middle value at least 1.2-fold (0.09 log units) away from the limit.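

No step can be read from compound 3 to compound 4, since both stand only at a limit in this assay: the limit of > 100000 nM in this assay, at which 3 of the 4 values shown sit. The compounds shown leave open whether methoxy in place of hydrogen on an aromatic carbon changes growth inhibition at all, in either direction.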